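Exchanging the Aryl Group on the Triazole Nitrogen: Cyanophenyl Forecast

The compounds below may be only part of what the source reports. "The series", "measured", "known", "first", "only" and "open" are said of these compounds alone.

Compound 1 `COc1ccccc1-n1cc(COc2c(/C=C\C(=O)O)ccc(OC)c2CC=C(C)C)nn1` gives 12200 nM
Compound 2 `COc1ccc(/C=C\C(=O)O)c(OCc2cn(-c3ccccc3)nn2)c1CC=C(C)C` gives 32300 nM
Compound 3 `COc1ccc(/C=C\C(=O)O)c(OCc2cn(-c3ccc(CO)cc3)nn2)c1CC=C(C)C` gives 19300 nM

All three share one core and differ only in the group on an aromatic nitrogen of the five-membered aromatic ring with three nitrogens. In a functional assay on COLO 205 cells (Homo sapiens) for cytotoxicity, read by MTT assay, with a stated time of 24 h (on this read-out higher numbers stand for weaker inhibition and lower numbers for stronger inhibition), compound 1 stands lowest of the three numbers. Removing its methoxy gave a 2.6-fold higher number from compound 1 to compound 2 (0.42 log units; beyond the scatter), whereas exchanging the whole aryl group gave a 1.6-fold higher number from compound 1 to compound 3 (0.20 log units; within the scatter), a change that stayed within the scatter.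

Compound 4 `COc1ccc(/C=C\C(=O)O)c(OCc2cn(-c3ccc(C#N)cc3)nn2)c1CC=C(C)C` carries the change (4-cyanophenyl in place of 2-methoxyphenyl on an aromatic nitrogen). Among the measured compounds shown here, the step from compound 1 to compound 3 is the closest precedent, since it also replaced the 2-methoxyphenyl by a para-substituted ring; it stayed within the scatter, so no step beyond the scatter is expected here either. Compound 4 is therefore estimated at 18000 nM, with a range from 8000 nM to 40000 nM. This estimate means a 1.5-fold higher number from compound 1 to compound 4 (0.17 log units; within the scatter).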

Compound 4, half-maximal inhibitory concentration: 32000 nM
Beside the measured number, compound 4's estimate is 1.8-fold (0.25 log units) below it, and the stated range covers the measured number.
By their numbers in this assay, from the lowest: compounds 1, 3, 4 and 2 (each within the scatter of the next, the first and the last beyond it).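

In this assay the 4-cyanophenyl group gives a 2.6-fold higher number from compound 1 to compound 4 (0.42 log units; beyond the scatter) and so, unlike the 4-(hydroxymethyl)phenyl group of compound 3, moves the number beyond the scatter when it replaces 2-methoxyphenyl. Adding the cyano group to the plain phenyl of compound 2 gives a 1.0-fold lower number from compound 2 to compound 4 (0.00 log units; within the scatter) and leaves the two compounds indistinguishable. Cyano in place of hydroxymethyl gives a 1.7-fold higher number from compound 3 to compound 4 (0.22 log units; within the scatter) and also stays within the scatter, so these two groups cannot be told apart here. No measurement shown explains these steps. On these data alone, whether an amine or a carboxylic acid in place of the cyano group would shift the number remains open.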